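The compounds below may be only part of what the source reports. "The series", "measured", "known", "first", "only" and "open" are said of these compounds alone.

For the measured compounds named here, compound 2 `CCCCCCCCCCc1cn(C[C@H](O)[C@H]2OC(=O)C(OCc3ccccc3)=C2OCc2ccccc2)nn1` in a functional assay on SW-620 cells (Homo sapiens) for antiproliferative activity, read by MTT assay, with a stated time of 72 h (a lower number here means a stronger inhibitor, a higher number a weaker inhibitor), gives 45200 nM, the only number so far. Compound 1 `Cc1ccc(-c2cn(C/C=C3\OC(=O)C(OCc4ccccc4)=C3OCc3ccccc3)nn2)cc1` reaches only a limit in this assay, > 100000 nM. That value sits at the limit of > 100000 nM in this assay, at which 1 of the 2 values shown sits. Compound 3 `O=C1O[C@H]([C@@H](O)Cn2cc(CCO)nn2)C(OCc2ccccc2)=C1OCc1ccccc1` is not yet measured; it differs from compound 2 by hydroxy in place of octyl on a saturated chain carbon, two bonds along the chain from an aromatic carbon. Going by the values given here, no measured step covers a change of this kind. The step from compound 2 to compound 3 is expected to run toward weaker inhibition, beyond the scatter, a 2.7-fold higher number from compound 2 to compound 3 (0.42 log units; beyond the scatter). For compound 3 the estimate in this assay is 120000 nM, within 40000 nM to 400000 nM, with a fair chance that only a limit is reported.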

Compound 3, half-maximal inhibitory concentration: > 100000 nM
Compound 3: a limit, no number; the forecaster's own chance of this, stated with the estimate: 60%; the middle value is on the limit's open side.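

In this assay, the change from octyl to hydroxy on a saturated chain carbon, two bonds along the chain from an aromatic carbon, gives the first step read at this position: an at least 2.2-fold higher number from compound 2 to compound 3 (0.34 log units; beyond the scatter). Compound 3 gives > 100000 nM, which is a limit, so the step has a lower bound only. Numbers remain scarce in this series: the limit of > 100000 nM in this assay, at which 2 of the 3 values shown sit.

From the compounds shown here alone, how far the decyl to 2-hydroxyethyl exchange really moves the value stays open. Also open, going by these compounds, is whether butyl, an amine or a carboxylic acid in place of octyl would give a number in this assay.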